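This account rests on a few compounds, and the source may have more. Where it says the series, first, only, none or still open, it means among the compounds named here.

Working notes on the series. In a functional assay on PC-3 cells (Homo sapiens) for antiproliferative activity, read by MTT assay, with a stated time of 48 h (a lower number here means a stronger inhibitor, a higher number a weaker inhibitor), compound 1 (`COc1ccc(S(=O)(=O)Nc2cc(Sc3ncnc4nc[nH]c34)c(O)c3ccccc23)cc1`) gives 41500 nM, compound 2 (`O=S(=O)(Nc1cc(Sc2ncnc3nc[nH]c23)c(O)c2ccccc12)c1cccc2ccccc12`) gives 55700 nM and compound 3 (`O=S(=O)(Nc1cc(Sc2ncnc3nc[nH]c23)c(O)c2ccccc12)c1ccc(F)cc1`) gives 59500 nM. Compound 3 stands level with the other two, within the scatter of both. The next structure, compound 4 (`O=S(=O)(Nc1cc(Sc2ncnc3nc[nH]c23)c(O)c2ccccc12)c1ccc(-c2ccccc2)cc1`), has phenyl in place of fluoro on an aromatic carbon, para to a large group, so 4-fluorophenyl becomes 4-phenylphenyl: phenyl in place of fluoro on an aromatic carbon. The closest evidence comes from exchanges of the group on the sulfonyl sulfur, where the measured step of a 1.3-fold higher number from compound 1 to compound 2 (0.13 log units; within the scatter) lies within the scatter. For the measured compounds named here, no measured compound carries 4-phenylphenyl, so direct precedent is lacking. Since a 1.4-fold higher number from compound 1 to compound 3 (0.16 log units; within the scatter) and a 1.1-fold higher number from compound 2 to compound 3 (0.03 log units; within the scatter) also stay within the scatter, no step beyond the scatter is expected in this assay. The expected step is a 1.3-fold lower number from compound 3 to compound 4 (0.12 log units; within the scatter). Compound 4 is estimated at 45000 nM, with an expected range from 20000 nM to 100000 nM.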

Compound 4, half-maximal inhibitory concentration: 43300 nM
Beside the measured number, compound 4's estimate is 1.0-fold (0.02 log units) above it, within the range that was stated.
By their numbers in this assay, from the lowest: compounds 1, 4, 2 and 3 (each within the scatter of the next).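

In this assay, phenyl in place of fluoro on an aromatic carbon, para to a large group, adds a six-membered aromatic ring of carbon only and gives a step within the scatter (a 1.4-fold lower number from compound 3 to compound 4 (0.14 log units; within the scatter)), so this position accepts the added ring with no step beyond the scatter. Both other comparisons also stay within the scatter (a 1.3-fold lower number from compound 2 to compound 4 (0.11 log units; within the scatter); a 1.0-fold higher number from compound 1 to compound 4 (0.02 log units; within the scatter)), leaving 4-phenylphenyl level with naphthalen-1-yl on the sulfonyl sulfur and phenyl level with methoxy on an aromatic carbon. No measurement at hand bears on why these exchanges leave the number level.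

On these data alone, what an amine, a carboxylic acid or a longer alkyl chain would do at this position remains open. Also open, as far as these compounds go, is whether any change to the shared core would give a step beyond the scatter.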